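A Second Chloro Group on the Shared Fused Core

This account rests on a few compounds, and the source may have more. Where it says the series, first, only, none or still open, it means among the compounds named here.

Compound 1 `ClCc1ccc(Cn2cnc3c(Cl)nc(Cl)nc32)cc1` carries two chloro groups on its fused core, and in a functional assay on OVCAR-4 cells (Homo sapiens) for cytotoxicity, read by sulforhodamine B assay, with a stated time of 48 h (a lower number here means a stronger inhibitor of growth, a higher number a weaker inhibitor of growth), compound 1 gives 18600 nM. Compound 2 `ClCc1ccc(Cn2cnc3ncnc(Cl)c32)cc1` keeps the same side arm but bears a single chloro group on the fused system; for compound 2 this assay reports "not determined" (no result reported), so compound 2 stands without a number of its own. Compound 3 `ClCc1ccc(Cn2cnc3nc(Cl)nc(Cl)c32)cc1` differs from compound 2 by one change, (chloro in place of hydrogen on an aromatic carbon). Within the data shown here, no step between two measured compounds is available here, so the size of the move in this assay can only be anticipated: a change of this kind is expected to stay within the usual scatter, with no confident direction. Compound 3 is expected to give about 20000 nM in this assay, within a range from 5000 nM to 80000 nM. This expectation rests on compound 1, which also carries two chloro groups and gives 18600 nM.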

Compound 3, concentration for total growth inhibition: 4160 nM
The estimate for compound 3 lay 4.8-fold (0.68 log units) above the measured number; the whole stated range lies above it.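

In this assay, among these compounds, compound 3 gives 4160 nM, but compound 2 has no number of its own, so no step between compound 2 and compound 3 can be read. The compounds shown leave open what the added chloro group does in this assay, and nothing shown offers a cause.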